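The source may hold more compounds than are shown below. What is called first, only, known or untested is meant among the compounds shown, and "the series" means these compounds.

Working notes on the series. The shared core appears in compound 1 `Nc1cc(N)c2nc(-c3ccccc3)c(Oc3ccc(Cl)c(Cl)c3)nc2c1`, compound 2 `COc1cc(CNc2nc3cc(N)cc(N)c3nc2-c2ccccc2)cc(OC)c1OC` and compound 3 `COc1ccc(Sc2nc3cc(N)cc(N)c3nc2-c2ccccc2)cc1`. In a functional assay on HCT-116 cells (Homo sapiens) for inhibition, read by sulforhodamine B assay, with a stated time of 48 h (on this read-out higher numbers stand for weaker inhibition of growth and lower numbers for stronger inhibition of growth), compound 1 gives 15800 nM. In this assay compound 2 gives 9770 nM, and compound 3 gives 14800 nM. For the measured compounds named here, on these three numbers compound 3 stands second highest, but both its neighbours sit within the scatter: the gap to compound 2 is small, and the one step measured in one place, a 1.1-fold lower number from compound 1 to compound 3 (0.03 log units; within the scatter), is also within the scatter although it swaps the whole aryl group attached to the core.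

Compound 4 `Nc1cc(N)c2nc(-c3ccccc3)c(Sc3ccc(F)cc3)nc2c1` is not yet measured. Relative to compound 3 the change is fluoro in place of methoxy on an aromatic carbon. Going by the values given here, no measured step touches this position on the six-membered ring of carbon only; the only step available, from compound 1 to compound 3, is a far larger structural change and still moved the number within the scatter. On that basis the step of no change at the digits printed from compound 3 to compound 4 (within the scatter) is expected to be none beyond the scatter in this assay. Compound 4 is therefore estimated at 14800 nM in this assay, with a range of 6000 nM to 36000 nM.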

Compound 4, concentration for 50% growth inhibition: 14800 nM
Beside the measured number, compound 4's estimate shows no gap at the digits printed; low and high end bracket the measured number.
By their numbers in this assay, from the lowest: compounds 2, 3, 4 and 1 (each within the scatter of the next).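

In this assay, for the compounds shown here, fluoro in place of methoxy on an aromatic carbon, para to a large group, gives no change at the digits printed from compound 3 to compound 4 (within the scatter), the first measured step at this position on the six-membered aromatic ring of carbon only. Methoxy and fluoro differ in heavy atoms and in hydrogen-bond acceptors, yet this read-out does not separate compound 3 from compound 4, so the position has now been tested directly and not only through a swap of the whole aryl group. The further step, a 1.1-fold lower number from compound 1 to compound 4 (0.03 log units; within the scatter), with (4-fluorophenyl)sulfanyl in place of 3,4-dichlorophenoxy, is a second exchange of the whole group on the core that stays within the scatter, alongside a 1.1-fold lower number from compound 1 to compound 3 (0.03 log units; within the scatter).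

Still open is whether a group of another kind at this position, such as an amine, a carboxylic acid or a longer chain, would give a step beyond the scatter, as the two groups shown there are both small and neither is charged. No measurement is at hand that bears on why the numbers stay together across these changes.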